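Carrying a Methoxy Step From One Core to Another

This account rests on a few compounds, and the source may have more. Where it says the series, first, only, none or still open, it means among the compounds named here.

Compound 1 `CCOC(=O)N1N=C(c2ccccc2)CC1c1cc(OC)c(OC)c(OC)c1` and compound 2 `CCOC(=O)N1N=C(c2ccc(OC)cc2)CC1c1cc(OC)c(OC)c(OC)c1` share a core and differ in one place. In a functional assay on A549 cells (Homo sapiens) for antiproliferative activity, read by MTT assay, with a stated time of 48 h (on this read-out higher numbers stand for weaker inhibition of growth and lower numbers for stronger inhibition of growth), compound 1 gives 6680 nM, and compound 2 gives 4690 nM. The change between them, (methoxy in place of hydrogen on an aromatic carbon), made a step of a 1.4-fold lower number from compound 1 to compound 2 (0.15 log units; within the scatter).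

Compound 3 `COC(=O)N1N=C(c2ccccc2)CC1c1ccc(OC)c(OC)c1` carries a different core; how its core differs from that of compound 1 is not broken down here. In this assay compound 3 gives 7320 nM, a number that lies within the scatter of both compound 1 and compound 2.

Compound 4 `COC(=O)N1N=C(c2ccccc2)CC1c1cc(OC)c(OC)cc1OC` has not yet been measured. It differs from compound 3 by methoxy in place of hydrogen on an aromatic carbon. For the measured compounds named here, this is the same kind of change as the one from compound 1 to compound 2, but not the same change: there the entering methoxy stood para to a large group, whereas here it stands ortho to a large group, meta to a methoxy group and para to a methoxy group.

The expectation for compound 4 rests on a single earlier step, a 1.4-fold lower number from compound 1 to compound 2 (0.15 log units; within the scatter), which stayed within the scatter. A similarly small step is therefore expected, a 1.3-fold lower number from compound 3 to compound 4 (0.12 log units; within the scatter), and since the surroundings of the place differ, the range is kept wide. For compound 4 in this assay the estimate is 5500 nM, with a likely span from 2500 nM to 14000 nM.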

Compound 4, concentration for 50% growth inhibition: 5320 nM
For compound 4 the middle estimate is 1.0-fold (0.01 log units) above the measured one; the measured number falls inside the stated range.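

In this assay, the new step for methoxy in place of hydrogen on an aromatic carbon is a 1.4-fold lower number from compound 3 to compound 4 (0.14 log units; within the scatter), and it matches the earlier step on the other core: the same change on two cores in this assay, a 1.4-fold lower number (0.15 log units; within the scatter) from compound 1 to compound 2 and a 1.4-fold lower number (0.14 log units; within the scatter) from compound 3 to compound 4, 1.0-fold (0.02 log units) apart, within the scatter of two such steps

For these two pairs, then, the change carries from one core to the other with no difference in the size of its step. What carries over, however, is only a small step that stays within the scatter on both cores, so the two pairs do not establish that a methoxy group at either place improves growth inhibition. Nor do they show that place is irrelevant or that the same result would hold on other cores, since the entering methoxy in compound 4 stands ortho to a large group, meta to a methoxy group and para to a methoxy group, which is not the place it takes in compound 2, and two pairs make no general rule.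

The compounds shown leave open whether an amine, a carboxylic acid or a longer alkoxy chain at the same place would give a step beyond the scatter. They also leave open whether any such step would keep its size from one core to the other.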